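Replacing the aryl group on the ring nitrogen in compound 3

This account rests on a few compounds, and the source may have more. Where it says the series, first, only, none or still open, it means among the compounds named here.

Two measured compounds share one core and differ only in the aryl group on the aromatic nitrogen. In an assay on CHO-K1 cells for antagonist activity at transient receptor potential cation channel subfamily V member 1 (Homo sapiens), read by FLIPR and calcium flux, with a stated time of 6 min (a higher number here means a weaker inhibitor, a lower number a stronger inhibitor), compound 1 `Cn1ncc2c(NC(=O)NCc3cc(C(F)(F)F)nn3-c3ccc(Cl)cc3)cccc21` gives 2.7 nM. In this assay compound 2 `Cn1ncc2c(NC(=O)NCc3cc(C(F)(F)F)nn3-c3ccc(C(F)(F)F)cc3)cccc21` gives 3.9 nM. Among the compounds with values here, the single step connecting them, a 1.4-fold higher number from compound 1 to compound 2 (0.16 log units; within the scatter), is small. Compound 2 thus has the higher of the two numbers, but its gap to compound 1 lies within the scatter, so nothing separates them in order.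

Compound 3 `Cn1ncc2c(NC(=O)NCc3cc(C(F)(F)F)nn3-c3ccc(F)c(F)c3)cccc21` carries a different aryl group: 3,4-difluorophenyl in place of 4-(trifluoromethyl)phenyl on an aromatic nitrogen. Within the data shown here, the only measured step that bears on this change is a 1.4-fold higher number from compound 1 to compound 2 (0.16 log units; within the scatter), where one substituent on the same phenyl ring was exchanged for another with no movement beyond the scatter. On that basis a further exchange of the aryl group is expected to give at most a small shift in this assay, with a slight lean toward a higher number. Compound 3 is therefore estimated at 5 nM, within a range of 1.5 nM to 16 nM. The expected step is a 1.3-fold higher number from compound 2 to compound 3 (0.11 log units; within the scatter).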

Compound 3, inhibition constant: 4.9 nM
Compound 3: the middle estimate sits 1.0-fold (0.01 log units) above what was measured, and the stated range covers the measured number.
By their numbers in this assay, from the lowest: compounds 1, 2 and 3 (each within the scatter of the next).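

Putting 3,4-difluorophenyl in place of 4-(trifluoromethyl)phenyl on the aromatic nitrogen gives a small step in this assay (a 1.3-fold higher number from compound 2 to compound 3 (0.10 log units; within the scatter)), and putting it in place of 4-chlorophenyl gives another (a 1.8-fold higher number from compound 1 to compound 3 (0.26 log units; within the scatter)). The earlier pair showed only that one substituent on the phenyl ring could be exchanged for another, whereas these steps extend that result to a ring carrying two fluorines. Across these three aryl groups, the position on the aromatic nitrogen therefore shows no change in this assay that stands beyond the scatter, and nothing available explains this result.

On these data alone, all three groups are phenyl rings bearing only fluorine, chlorine or trifluoromethyl, so it remains open whether this insensitivity would hold for a phenyl ring carrying an amine or a carboxylic acid. As far as these compounds go, it is equally open whether the same result would follow if a pyridine ring or a saturated alkyl chain took the place of the phenyl ring on that nitrogen.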